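A Methoxy for a Methyl on a Weak Series

A few compounds are considered here, and "the series" means these few. Any claim that something is new, unique, unknown or untested is made for them only; others in the source may bear on it.

Measured so far in a functional assay on OE19 cells (Homo sapiens) for cytotoxicity, read by MTT assay, with a stated time of 48 h; a lower number here means a stronger inhibitor, a higher number a weaker inhibitor:
compound 1, `CC1(C)S[C@@H]2/C(=C\C(=O)c3ccco3)C(=O)N2[C@H]1C(=O)OC(c1ccccc1)c1ccccc1`, gives 54300 nM
compound 2, `CC(=O)/C=C1\C[C@H]2SC(C)(C)[C@H](C(=O)OC(c3ccccc3)c3ccccc3)N2C1=O`, gives only a limit, > 100000 nM
compound 3, `CC1(C)S[C@@H]2/C(=C\C(=O)c3ccc([N+](=O)[O-])cc3)C(=O)N2[C@H]1C(=O)OC(c1ccccc1)c1ccccc1`, gives 44100 nM

Among the measured compounds shown here, compound 2 stands apart from the other two in that its result is not a number but a limit of this assay, (the limit of > 100000 nM in this assay, at which 1 of the 3 values shown sits); it is the one compound of the three that lies there, so its true value is unknown beyond that mark.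

The unmeasured compound 4, `COC(=O)/C=C1\C[C@H]2SC(C)(C)[C@H](C(=O)OC(c3ccccc3)c3ccccc3)N2C1=O`, differs from compound 2 in one place: methoxy in place of methyl on a carbonyl carbon.

For the measured compounds named here, only one measured step changes a group on a carbonyl carbon, and it comes from the other pair: a 1.2-fold lower number from compound 1 to compound 3 (0.09 log units; within the scatter). That change swaps a much larger group than the one here, and both of its compounds are well inside the measurable range, so it is an indirect guide at best. It suggests that a change at the carbonyl carbon leaves the number about where it was, with no step beyond the scatter.

Compound 4 is therefore expected to sit near the limit as well, with the estimated step of a number no higher from compound 2 to compound 4 (the limit leaves the size open). The expected value for compound 4 is 100000 nM, within a range of 40000 nM to 300000 nM, and a limit rather than a number is the likelier outcome.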

Compound 4, half-maximal inhibitory concentration: 99700 nM
The estimate for compound 4 lay 1.0-fold (0.00 log units) above the measured number; low and high end bracket the measured number.
By their numbers in this assay, from the lowest: compounds 3, 1 and 4 (each within the scatter of the next, the first and the last beyond it). At a limit, above all of these: compound 2.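

In this assay, compound 4 gives 99700 nM, so methoxy in place of methyl on this carbonyl carbon yields a real number. Compound 2 remains a limit of the assay: the limit of > 100000 nM in this assay, at which 1 of the 4 values shown sits.

The change therefore reads as a number no higher from compound 2 to compound 4 (the limit leaves the size open), which means that its size cannot be read: the swap from acetyl to methoxycarbonyl, which adds an oxygen and a hydrogen-bond acceptor, could have done almost nothing or could have helped considerably.

The compounds shown leave open whether any group on this carbonyl carbon can move the number clearly, since one end of the only step here is a limit and the other lies close to that limit. An amine on the same carbon, which would give an amide, a hydroxyl, which would give a carboxylic acid, or a longer chain such as ethoxy in place of methoxy would each test this position against compound 4, which has a number to compare with.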